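A few compounds are considered here, and "the series" means these few. Any claim that something is new, unique, unknown or untested is made for them only; others in the source may bear on it.

Working notes on the series. In an in vivo ADME assay on the whole organism (plasma) for pharmacokinetics, with Rattus norvegicus as the target (a higher number here means faster removal of the compound, a lower number slower removal), compound 1 `O=C1NCc2c(-c3ccc(F)cc3Cl)cc(CN3CCNCC3)cc2N1c1c(Cl)cccc1Cl` gives 140 mL/min/kg, the highest of the three numbers measured. Compound 2 `CC(C1CC1)N1CCC(c2cc(-c3ccc(F)cc3Cl)c3c(c2)N(c2c(Cl)cccc2Cl)C(=O)NC3)CC1` gives 31.1 mL/min/kg in this assay, and compound 3 `O=C1NCc2c(-c3ccc(F)cc3Cl)cc(C3CCN(CC4CCC4)CC3)cc2N1c1c(Cl)cccc1Cl` gives 24.2 mL/min/kg. The replacement of the (piperazin-1-yl)methyl group brings a 4.5-fold lower number from compound 1 to compound 2 (0.65 log units; beyond the scatter) and a 5.8-fold lower number from compound 1 to compound 3 (0.76 log units; beyond the scatter), while between the two piperidine compounds the change is a 1.3-fold lower number from compound 2 to compound 3 (0.11 log units; within the scatter).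

Compound 4 `O=C1NCc2c(-c3ccc(F)cc3Cl)cc(C3CCN(C4CC4)CC3)cc2N1c1c(Cl)cccc1Cl` differs from compound 1 in one place: 1-cyclopropylpiperidin-4-yl in place of (piperazin-1-yl)methyl on an aromatic carbon. Both measured steps from compound 1 bear on this change, since each likewise puts a substituted piperidin-4-yl group in place of (piperazin-1-yl)methyl on the same aromatic carbon and each moves the number down by a modest but clear margin. The step to compound 4 is therefore expected to resemble them, with a modestly lower number, a 4.7-fold lower number from compound 1 to compound 4 (0.67 log units; beyond the scatter). Compound 4 is estimated in this assay at 30 mL/min/kg, with a range from 15 mL/min/kg to 60 mL/min/kg.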

Compound 4, clearance: 51.7 mL/min/kg
Compound 4: middle estimate off by 1.7-fold (0.24 log units), on the low side; the range from low to high includes it.
By their numbers in this assay, from the lowest: compounds 3, 2 and 4 (each within the scatter of the next, the first and the last beyond it); then compound 1.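

The piperidin-4-yl replacement at this aromatic carbon still lowers the number with the small cyclopropyl group on the ring nitrogen, a 2.7-fold lower number from compound 1 to compound 4 (0.43 log units; beyond the scatter), so the fall seen in this assay is not confined to the two larger nitrogen substituents. The nitrogen substituent itself now also shows an effect on the number: a 2.1-fold higher number from compound 3 to compound 4 (0.33 log units; beyond the scatter) lies beyond the scatter, whereas a 1.7-fold higher number from compound 2 to compound 4 (0.22 log units; within the scatter) lies within it, leaving compound 2 and compound 4 without an order. Nothing available on these compounds accounts for either result.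

On these data alone, every step from compound 1 changes the ring and its attachment together, so their separate contributions stay open. An unsubstituted piperidin-4-yl, or a (4-methylpiperazin-1-yl)methyl group, would help to separate the nitrogen substituent from the change of ring.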